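A few compounds are considered here, and "the series" means these few. Any claim that something is new, unique, unknown or untested is made for them only; others in the source may bear on it.

Measured compounds:
compound 1 `Cn1ncc(Cl)c1-c1cc(C(=O)N[C@@H]2CN[C@H](CCN3CCCC3)C[C@H]2c2ccc(Cl)c(Cl)c2)oc1Cl` — 6.41 nM
compound 2 `CNC(=O)C[C@@H]1C[C@@H](c2ccc(F)c(F)c2)[C@H](NC(=O)c2cc(-c3c(Cl)cnn3C)c(Cl)o2)CN1` — 1.37 nM

Of the compounds shown here, two have been measured in an assay for inhibition of RAC-alpha serine/threonine-protein kinase (Homo sapiens), read by HTRF, with a stated time of 1 h; on this read-out higher numbers stand for weaker inhibition and lower numbers for stronger inhibition. Compound 1 `Cn1ncc(Cl)c1-c1cc(C(=O)N[C@@H]2CN[C@H](CCN3CCCC3)C[C@H]2c2ccc(Cl)c(Cl)c2)oc1Cl` gives 6.41 nM and so carries the higher of the two numbers. Compound 2 `CNC(=O)C[C@@H]1C[C@@H](c2ccc(F)c(F)c2)[C@H](NC(=O)c2cc(-c3c(Cl)cnn3C)c(Cl)o2)CN1` gives 1.37 nM, a lower number, and the gap between the two lies beyond the usual scatter of such measurements. Among the compounds with values here, no pair of measured compounds differing in a single place is available, so no measured step can be read directly.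

The account now turns to compound 3 `Cn1ncc(Cl)c1-c1cc(C(=O)N[C@@H]2CN[C@H](CC(=O)NCCO)C[C@H]2c2ccc(Cl)c(Cl)c2)oc1Cl`, which has not yet been measured in this assay. It is derived from compound 1 by a single change: (2-hydroxyethyl)carbamoyl in place of (pyrrolidin-1-yl)methyl on a saturated chain carbon bound to a saturated ring carbon. The basic ring of compound 1 gives way to an open chain carrying a hydroxyl and an amide.

For the step from compound 1 to compound 3 a modest move toward a lower number is expected, roughly a 1.8-fold lower number from compound 1 to compound 3 (0.26 log units; within the scatter), though a step of this size may not exceed the scatter. Compound 3 is therefore estimated at 3.5 nM, with a plausible range from 1 nM to 12 nM.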

Compound 3, half-maximal inhibitory concentration: 1.41 nM
Beside the measured number, compound 3's estimate is 2.5-fold (0.39 log units) above it; the measured number falls inside the stated range.
By their numbers in this assay, from the lowest: compounds 2 and 3 (each within the scatter of the next); then compound 1.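

In this assay, within the data shown here, the change from (pyrrolidin-1-yl)methyl to (2-hydroxyethyl)carbamoyl on a saturated chain carbon bound to a saturated ring carbon gives a 4.5-fold lower number from compound 1 to compound 3 (0.66 log units; beyond the scatter) and so provides the first step in this set that can be read at a single place. With the core of compound 1 held constant, this position accepts an open chain of the same heavy-atom count, with no ring and with more hydrogen-bond donors and acceptors, and the number falls by more than the scatter. Nothing shown gives a reason for this step, so its size cannot be assigned to the loss of the ring, the entering carbonyl or the hydroxyl.

The compounds shown do not separate the contributions of the amide and the hydroxyl, and it remains open how a simple ethyl amide, a carboxylic acid or a longer chain carrying a terminal hydroxyl would read at this place. Going by these compounds, it is also open whether the same change would give a step of similar size on a core bearing a different aryl group, such as the 3,4-difluorophenyl ring of compound 2.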